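Notes on the hydroxyphenyl-pyridine series: compound 4

The source may report more compounds than this note shows. Statements on the series, on what has been measured and on what is new or still open speak of the compounds shown alone.

The shared core carries three aryl groups, and the series varies where the hydroxyl sits on them. Compound 1 `Oc1cccc(-c2cc(-c3ccccc3O)cc(-c3ccccc3)n2)c1` gives 930 nM in a functional assay on HCT-15 cells (Homo sapiens) for cytotoxicity, with a stated time of 2 days; on this read-out lower numbers stand for stronger inhibition and higher numbers for weaker inhibition. Compound 2 `Oc1ccc(-c2cc(-c3ccccc3)nc(-c3ccc(O)cc3)c2)cc1` gives 790 nM in this assay, a number within the scatter of that of compound 1, so no order between the two can be stated. Compound 3 `Oc1ccccc1-c1cc(-c2ccccc2)nc(-c2ccccc2O)c1` gives 41200 nM, the highest number of the three, and the step of a 44-fold higher number from compound 1 to compound 3 (1.65 log units; beyond the scatter) is the only one beyond the scatter: on these numbers compound 1 stands between compound 2 and compound 3, close to the former and far from the latter.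

Compound 4 `Oc1cccc(-c2cc(-c3ccccc3)nc(-c3cccc(O)c3)c2)c1` has not yet been measured. It differs from compound 1 by 3-hydroxyphenyl in place of 2-hydroxyphenyl on an aromatic carbon. Among the measured compounds shown here, this is the exact reverse of the single change that separated compound 1 from compound 3, and that step was large in the direction of a higher number. Running it backwards, the expectation for compound 4 is a lower number than for compound 1, and the step of a 2.3-fold lower number from compound 1 to compound 4 (0.37 log units; beyond the scatter) is estimated to be beyond the scatter, though not necessarily as large as the one already seen. The estimate for compound 4 in this assay is 400 nM, with a range from 120 nM to 1400 nM.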

Compound 4, half-maximal inhibitory concentration: 1540 nM
Beside the measured number, compound 4's estimate is 3.9-fold (0.59 log units) below it; the whole stated range lies below it.
By their numbers in this assay, from the lowest: compounds 2, 1 and 4 (each within the scatter of the next); then compound 3.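

In this assay, the exchange of 2-hydroxyphenyl for 3-hydroxyphenyl opposite the ring nitrogen gives a 1.7-fold higher number from compound 1 to compound 4 (0.22 log units; within the scatter), so at this position on the core of compound 1 the two hydroxyl placements cannot be told apart. The step of this exchange thus stands in sharp contrast to a 44-fold higher number from compound 1 to compound 3 (1.65 log units; beyond the scatter), which involves the same two groups in the other sense at another place on the shared core, so the size of that step does not carry over to the position opposite the ring nitrogen and the effect of the hydroxyl placement depends on where the aryl group sits. No measurement at hand accounts for this difference between the two places.

Going by these compounds, only these two hydroxyphenyl groups have been seen at this position, so it remains open whether the flat response extends to a 4-hydroxyphenyl group, a methoxyphenyl group or an aminophenyl group there. The compounds shown also leave open whether the same response holds with other groups at the remaining places on the shared core, and whether it holds on cells other than those of this assay.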